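Notes on compound 4, the ethoxy analogue in this series

This account rests on a few compounds, and the source may have more. Where it says the series, first, only, none or still open, it means among the compounds named here.

Measured in a functional assay on MDA-MB-231 cells (Homo sapiens) for inhibition, read by MTT assay, with a stated time of 72 h; on this read-out higher numbers stand for weaker inhibition and lower numbers for stronger inhibition:
compound 1 `Cc1ccc(-c2cc(C(=O)N3CCC4(CC3)CC(=O)c3nn(C(C)(C)C)cc3O4)c3ccccc3n2)cc1` — > 10000 nM, a limit of the assay
compound 2 `CC(C)(C)n1cc2c(n1)C(=O)CC1(CCN(C(=O)c3cc(-c4ccc(Br)cc4)nc4ccccc34)CC1)O2` — > 10000 nM, a limit of the assay
compound 3 `CN(C)c1ccc(-c2cc(C(=O)N3CCC4(CC3)CC(=O)c3nn(C(C)(C)C)cc3O4)c3ccccc3n2)cc1` — > 10000 nM, a limit of the assay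

Compound 2 stands only at a limit and carries no number; all three values shown sit at that limit (the limit of > 10000 nM in this assay, at which 3 of the 3 values shown sit). The measured steps a step that the two limits leave unreadable from compound 1 to compound 2, a step that the two limits leave unreadable from compound 1 to compound 3 and a step that the two limits leave unreadable from compound 2 to compound 3 are thus unreadable in size and direction, and they concern a group on the phenyl ring, which compound 4 no longer carries.

Compound 4 `CCOc1cc(C(=O)N2CCC3(CC2)CC(=O)c2nn(C(C)(C)C)cc2O3)c2ccccc2n1` differs from compound 2 by ethoxy in place of 4-bromophenyl on an aromatic carbon. Among the measured compounds shown here, no measured step bears directly on this change. With every value in the set resting at the limit (the limit of > 10000 nM in this assay, at which 3 of the 3 values shown sit), the expectation for compound 4 is that it again sits at or beyond that limit, the step that the limit leaves unreadable from compound 2 to compound 4 being expected to change nothing readable. Compound 4 is estimated at 15000 nM, with a range from 5000 nM to 50000 nM.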

Compound 4, half-maximal inhibitory concentration: > 10000 nM
Compound 4 ended at the assay's limit; the forecaster's own chance of this, stated with the estimate: 80%; the middle value does not contradict the limit.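

Compound 4 joins compound 1, compound 2 and compound 3 at a limit in this assay, so no step from any of them to compound 4 can be read in size or direction: the limit of > 10000 nM in this assay, at which 4 of the 4 values shown sit.

The compounds shown leave open how far each lies beyond that limit, and whether ethoxy and the phenyl groups differ at all.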